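The source may report more compounds than this note shows. Statements on the series, on what has been measured and on what is new or still open speak of the compounds shown alone.

Compound 1 `CCC(C)Oc1ccccc1-c1ncc(C(=O)O)c(=O)[nH]1`: 0.5 mg/kg
Compound 2 `CCCCCOc1ccccc1-c1ncc(C(=O)O)c(=O)[nH]1`: 3 mg/kg
Compound 3 `CCOC(=O)c1cnc(-c2ccccc2OC(C)CC)[nH]c1=O`: 0.5 mg/kg

These three compounds were measured in a functional assay on the whole organism (strain Sprague-Dawley) for inhibition, with Rattus norvegicus as the target, with a stated time of 10 min; a higher number here means that more compound is needed for the effect, a lower number that less compound is needed. Compound 4 `CCCCCOc1ccccc1-c1ncc(C(=O)OCC)c(=O)[nH]1` has not yet been measured there. Compound 3 differs from compound 1 by ethyl in place of hydrogen on an oxygen next to a carbonyl group, and that step gave no change at the digits printed from compound 1 to compound 3 (within the scatter). Compound 4 arises from compound 3 by pentyl in place of sec-butyl on an oxygen on an aromatic ring. The same change was made once before, from compound 1 to compound 2, namely (pentyl in place of sec-butyl on an oxygen on an aromatic ring), and it gave a 6.0-fold higher number from compound 1 to compound 2 (0.78 log units; beyond the scatter). As the place of the change is the same in both pairs and compound 3 stands level with compound 1 in this assay, the step from compound 3 to compound 4 is expected to be a 6.0-fold higher number from compound 3 to compound 4 (0.78 log units; beyond the scatter), resting on a 6.0-fold higher number from compound 1 to compound 2 (0.78 log units; beyond the scatter). Compound 4 is thus estimated at 3 mg/kg in this assay, within a range from 1.5 mg/kg to 6 mg/kg.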

Compound 4, dose for 50% inhibition: 2 mg/kg
Estimate against measurement, compound 4: 1.5-fold (0.18 log units) above; the range from low to high includes it.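

In this assay, pentyl in place of sec-butyl gave a 4.0-fold higher number from compound 3 to compound 4 (0.60 log units; beyond the scatter), so this step carried over between the two cores: the same change on two cores in this assay, a 6.0-fold higher number (0.78 log units; beyond the scatter) from compound 1 to compound 2 and a 4.0-fold higher number (0.60 log units; beyond the scatter) from compound 3 to compound 4, 1.5-fold (0.18 log units) apart, within the scatter of two such steps. Ethyl in place of hydrogen on an oxygen next to a carbonyl group gave a 1.5-fold lower number from compound 2 to compound 4 (0.18 log units; within the scatter), so this step, too, held on both cores, with neither step beyond the scatter: the same change on two cores in this assay, no change at the digits printed (within the scatter) from compound 1 to compound 3 and a 1.5-fold lower number (0.18 log units; within the scatter) from compound 2 to compound 4, 1.5-fold (0.18 log units) apart, within the scatter of two such steps. This rests on only four compounds in a single assay, and it does not show that either change would carry over to any other core, or why the steps agree.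

The compounds shown leave open how a longer chain such as hexyl or a benzyl group on the same oxygen would behave. They also leave open whether an amide in place of the carboxylic acid or ester would follow the same pattern.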